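Swapping the Ester Tail: From Compound 2 to Compound 4

This account rests on a few compounds, and the source may have more. Where it says the series, first, only, none or still open, it means among the compounds named here.

Measured compounds:
compound 1 `CCCCCOC(=O)c1cccc(-c2cc(C(=O)Nc3ccncc3)ccc2CN)c1` — 0.967 h
compound 2 `CC(C)OCCOC(=O)c1cccc(-c2cc(C(=O)Nc3ccncc3F)ccc2CN)c1` — 0.1 h
compound 3 `CCOC(=O)c1cccc(-c2cc(C(=O)Nc3ccncc3)ccc2CN)c1` — 0.683 h

The read-out throughout is an ADME assay on a cell-free system (plasma, Homo sapiens) for metabolic stability, read by LC-MS; a higher number here means that the compound lasts longer, a lower number that the compound disappears faster. In this assay compound 2 gives the lowest of the three numbers; compound 3 and compound 1 both sit above it by more than the scatter, compound 3 being the nearer of the two.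

Compound 4 `NCc1ccc(C(=O)Nc2ccncc2F)cc1-c1cccc(C(=O)OCC2CC2)c1` has not been measured yet. Its change from compound 2 is cyclopropyl in place of isopropoxymethyl on a saturated chain carbon bound to an oxygen next to a carbonyl group.

For the measured compounds named here, only one measured step touches the same part of the molecule, the ester chain: a 1.4-fold lower number from compound 1 to compound 3 (0.15 log units; within the scatter). Compound 2 and compound 3 differ in two places at once, the ester chain and the fluorine, so their gap cannot be assigned to either change alone; their values merely show compound 2 far below compound 3.

Going by the values given here, since the one clean step on the ester chain stayed within the scatter, yet the compound carrying the isopropoxyethyl chain is the one with the short half-life, compound 4 is expected to move back up, with wide uncertainty. The estimated step is a 4.0-fold higher number from compound 2 to compound 4 (0.60 log units; beyond the scatter). For compound 4 the expected value is 0.4 h, with a range from 0.1 h to 1.2 h.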

Compound 4, half-life: 0.3 h
For compound 4 the middle estimate is 1.3-fold (0.12 log units) above the measured one; low and high end bracket the measured number.
By their numbers in this assay, from the lowest: compound 2; then compound 4; then compounds 3 and 1 (each within the scatter of the next).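

In this assay, replacing isopropoxymethyl with cyclopropyl on the saturated chain carbon bound to an oxygen next to a carbonyl group gives a 3.0-fold higher number from compound 2 to compound 4 (0.48 log units; beyond the scatter) with the fluorine present in both compounds. For the compounds shown here, this is the first clean pair to show that a change in the ester chain alone can move the half-life beyond the scatter, something the earlier compounds could not show: compound 2 and compound 3 differ in two places, while the one earlier step on this chain stayed within the scatter. The data shown offer no measurement that explains the difference between these two ester chains.

This single change removes the ether oxygen, alters the size of the chain and introduces a three-membered ring all at once, and the compounds shown do not separate those features or reveal the effect of the fluorine by itself. Also open, from the compounds shown here alone, is how the same fluorinated compound would behave with a straight butyl chain or a cyclobutylmethyl group on the ester, or with an amide in place of the ester.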